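The source may report more compounds than this note shows. Statements on the series, on what has been measured and on what is new or still open speak of the compounds shown alone.

Measured compounds, with their results in an ADME assay on cells (Fibroblast, Homo sapiens) for antiproliferative activity, with a stated time of 48 h (a lower number here means a stronger inhibitor, a higher number a weaker inhibitor), as follows

Compound 1 `CCN(CC)c1ccc(-c2cccc(OC)c2)nn1` gives > 25000 nM
Compound 2 `CC(=O)c1ccc(-c2ccc(N3CCCC3)nn2)cc1` gives > 25000 nM
Compound 3 `CCN(CC)c1ccc(-c2ccc(C(C)=O)cc2)nn1` gives > 25000 nM

Each of these results is a limit of the assay and not a number. Compound 3 therefore has only its limit > 25000 nM to mark its place, and the other two compounds offer nothing firmer, as the limit of > 25000 nM in this assay, at which 3 of the 3 values shown sit, shows.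

Compound 4 `CCOC(=O)c1ccc(-c2ccc(N(CC)CC)nn2)cc1` differs from compound 3 by one change (ethoxy in place of methyl on a carbonyl carbon), ethoxy in place of methyl on a carbonyl carbon, which turns acetyl into ethoxycarbonyl. Among the compounds with values here, the only measured step, a step that the two limits leave unreadable from compound 2 to compound 3, concerns a different group and has no readable size, so it offers no size to carry over. Within the data shown here, no measured step touches the acetyl group. In this assay, among the measured compounds shown here, no step beyond the scatter can be expected in either direction, and a further limit is the likeliest result because the limit of > 25000 nM in this assay, at which 3 of the 3 values shown sit, holds for every compound so far. The expected change is a number no higher from compound 3 to compound 4 (the limit leaves the size open) and it stays uncertain. For compound 4 the estimate is 25000 nM, with an expected range from 10000 nM to 50000 nM.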

Compound 4, half-maximal inhibitory concentration: 3000 nM
Compound 4: the middle estimate sits 8.3-fold (0.92 log units) above what was measured, and the stated range ends above it.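

In this assay, within the data shown here, replacing methyl with ethoxy on the carbonyl carbon gives an at least 8.3-fold lower number from compound 3 to compound 4 (0.92 log units; beyond the scatter), the first step in this set whose size can be read. Among these compounds, this shows that the group on this carbonyl carbon can change the result, something the earlier compounds could not show. Compound 4 is also the only compound shown that gives a number and not a limit of the assay: the limit of > 25000 nM in this assay, at which 3 of the 4 values shown sit.

The compounds shown leave open which part of ethoxy matters, the oxygen or the ethyl chain, and how far the step could go, since a carboxylic acid, an amide or a longer chain on the same carbonyl carbon would each separate these possibilities. They also leave open whether ethoxycarbonyl would give a measurable result with pyrrolidin-1-yl in place of diethylamino.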